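A few compounds are considered here, and "the series" means these few. Any claim that something is new, unique, unknown or untested is made for them only; others in the source may bear on it.

Within the data shown here, compound 2 `CC1=C(C(=O)Nc2ccc([N+](=O)[O-])cc2)C(c2ccc(Br)cc2)N=C(SCc2ccc(Cl)cc2)N1` is one of only two compounds measured in a functional assay on the whole organism (artery, strain albino) with Rattus norvegicus as the target, with a stated time of 60 min, at a dose of 10 mg/kg by the oral route; on this read-out higher numbers stand for more inhibition at the one dose given (going by the name of the read-out) and lower numbers for less inhibition; there compound 2 gives 10.8%. Among the measured compounds shown here, its nearest neighbour is compound 1 `CC1=C(C(=O)Nc2ccc([N+](=O)[O-])cc2)C(c2ccc(Br)cc2)N=C(SCc2cccc(Cl)c2)N1`, which in this assay gives 4.1%, and the single step between them, a number 6.7 percentage points higher from compound 1 to compound 2 (within the scatter), lies within the scatter, so compound 2 holds the larger of the two numbers on paper but is not separated from compound 1. Compound 3 `CC1=C(C(=O)Nc2ccc([N+](=O)[O-])cc2)C(c2ccc(Br)cc2)N=C(SCc2ccc(F)cc2)N1` differs from compound 2 by one change: fluoro in place of chloro on an aromatic carbon. For the measured compounds named here, no measured step exchanges one halogen for another on this ring; the only step available swaps 3-chlorophenyl for 4-chlorophenyl, bears on the present change only indirectly, and was itself small. A step of a number 0.8 percentage points lower from compound 2 to compound 3 (within the scatter) is therefore expected, staying inside the scatter in either direction. The estimate for compound 3 in this assay is 10%, with a range from 0% to 22%.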

Compound 3, a percentage reported as inhibition, in the whole organism at one dose (the size of the read-out at that dose, not a potency): 9.7%
Beside the measured number, compound 3's estimate is 0.3 percentage points above it; measured number inside the range.
By their numbers in this assay, from the lowest: compounds 1, 3 and 2 (each within the scatter of the next).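

Within this assay, this is the first exchange of one halogen for another on this ring: fluoro in place of chloro on an aromatic carbon, para to a large group, gives a step that does not separate the two compounds (a number 1.1 percentage points lower from compound 2 to compound 3 (within the scatter)). Moving from a 3-chlorophenyl to a 4-fluorophenyl changes both the halogen and its place, and this too leaves the compounds unseparated (a number 5.6 percentage points higher from compound 1 to compound 3 (within the scatter)). Nothing measured here gives a reason for these results.

The compounds shown leave open whether a group of another kind at this place, such as an amine or a carboxylic acid in place of the halogen, would move the number beyond the scatter. They also leave open what a longer chain between the sulfur and the ring would do.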